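Replacing 4-carboxycyclohexyl with 8-hydroxyquinolin-5-yl

The source may hold more compounds than are shown below. What is called first, only, known or untested is meant among the compounds shown, and "the series" means these compounds.

In a functional assay on U-87MG ATCC cells (Homo sapiens) for antiproliferative activity, with a stated time of 3 days (a higher number here means that more compound is needed for the effect, a lower number that less compound is needed), compound 1 `Oc1ccc(CN(Cc2cccs2)Cc2ccc(O)c3ncccc23)c2cccnc12` gives < 0.2 uM, which is a limit of the assay and not a number. Compound 2 `O=C(O)C1CCC(CN(Cc2ccc(O)c3ncccc23)Cc2ccc(O)c3ncccc23)CC1` offers no number at all: its result reads "not determined" (no result reported). Among the measured compounds shown here, compound 2 therefore has no place on this scale, and no measured step is available as a guide. Compound 3 `Oc1ccc(CN(Cc2ccc(O)c3ncccc23)Cc2ccc(O)c3ncccc23)c2cccnc12` has not yet been measured. The change 8-hydroxyquinolin-5-yl in place of 4-carboxycyclohexyl on a saturated chain carbon bound to an amine nitrogen puts 8-hydroxyquinolin-5-yl in place of 4-carboxycyclohexyl on a saturated chain carbon bound to an amine nitrogen. The same group is present in compound 1, whose < 0.2 uM is again only a limit. On that sole ground, a step beyond the usual scatter is expected, towards less compound needed. For compound 3, the estimated value in this assay is 0.2 uM, with an expected range from 0.05 uM to 1 uM.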

Compound 3, concentration for half-maximal effect: > 10 uM
Compound 3 gave a limit, no number (the forecaster's own chance of this, stated with the estimate: 45%); at least 50-fold (1.69 log units) between middle value and limit.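

At this position, on a saturated chain carbon bound to an amine nitrogen, the choice of group matters greatly in this assay: putting 8-hydroxyquinolin-5-yl in place of thiophen-2-yl gives an at least 50-fold higher number from compound 1 to compound 3 (1.69 log units; beyond the scatter). Compound 1 already carries 8-hydroxyquinolin-5-yl elsewhere, so having this group in one part of the molecule says little about its effect at this place. The value of compound 3 is a limit and not a number: the limit of > 10 uM in this assay, at which 1 of the 3 values shown sits.

The value of compound 1 is also a limit and not a number, which leaves the true size of the step open: the limit of < 0.2 uM in this assay, at which 1 of the 3 values shown sits. Nothing shown explains the change, and with no result for compound 2, it remains unknown how 4-carboxycyclohexyl, a plain phenyl ring or a simple amine on a longer chain would fare at this place.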